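Methoxycarbonyl in place of dimethylamino: working notes

The source may report more compounds than this note shows. Statements on the series, on what has been measured and on what is new or still open speak of the compounds shown alone.

Measured so far in an ADME assay on HepG2 cells (Homo sapiens) for cytotoxicity, with a stated time of 72 h; a higher number here means that more compound is needed for the effect, a lower number that less compound is needed
compound 1 `Cc1cc(NC(=O)Nc2ccc(C(C)(C)C)cc2)c2ccccc2n1` gives 17000 nM
compound 2 `Cc1cc(NC(=O)Nc2ccc(N(C)C)cc2)c2ccccc2n1` gives > 25000 nM as a limit

Compound 2 reads > 25000 nM and that is a limit of the assay, not a number. Among the measured compounds shown here, the series so far shows the limit of > 25000 nM in this assay, at which 1 of the 2 values shown sits, and nothing further up. Compound 3 `COC(=O)c1ccc(NC(=O)Nc2cc(C)nc3ccccc23)cc1` carries methoxycarbonyl in place of dimethylamino on an aromatic carbon, para to a large group (methoxycarbonyl in place of dimethylamino on an aromatic carbon) in the otherwise shared structure. For the measured compounds named here, one measured step bears on this carbon, namely an at least 1.4-fold higher number from compound 1 to compound 2 (0.16 log units; that floor lies within the scatter) and so it offers no size beyond the scatter to carry over. Only compound 1 at 17000 nM gives a true number in this series. No step beyond the scatter is therefore expected, and the estimated move is an at least 1.2-fold lower number from compound 2 to compound 3 (0.09 log units; that floor lies within the scatter) in either direction. For compound 3 the estimate is 20000 nM with 9000 nM to 40000 nM as the expected range.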

Compound 3, half-maximal effective concentration: 20000 nM
The estimate for compound 3 equals the measured number at the digits printed; the measured number falls inside the stated range.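

In this assay, methoxycarbonyl in place of tert-butyl on an aromatic carbon gives a 1.2-fold higher number from compound 1 to compound 3 (0.07 log units; within the scatter), so this position now has a second true number, and the two groups cannot be told apart at it. Methoxycarbonyl in place of dimethylamino gives an at least 1.2-fold lower number from compound 2 to compound 3 (0.09 log units; that floor lies within the scatter), which is a floor and not a measured size. The value of compound 2 is a limit and not a number: the limit of > 25000 nM in this assay, at which 1 of the 3 values shown sits.

Going by these compounds, whether dimethylamino truly differs from methoxycarbonyl or tert-butyl at this carbon stays open while compound 2 has only a limit. Also open, on these data alone, is whether a carboxylic acid, a primary amine or a longer chain at this carbon would move the number beyond the scatter, and whether any change elsewhere in the shared core would do so.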